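A Trifluoromethyl Added to a Weakly Inhibiting Series

The source may report more compounds than this note shows. Statements on the series, on what has been measured and on what is new or still open speak of the compounds shown alone.

Compound 1 `CCCc1cc2ccccc2nc1-c1cc(-c2ccccc2)no1`, compound 2 `CCCCc1cc2ccccc2nc1-c1cc(-c2ccccc2)no1` and compound 3 `CCCCCc1cc2ccccc2nc1-c1cc(-c2ccccc2)no1` share one core and differ only in the length of the saturated chain. In a functional assay on A549 cells (Homo sapiens) for inhibition, read by MTT assay, with a stated time of 24 h (a higher number here means a weaker inhibitor, a lower number a stronger inhibitor), compound 1 gives 52500 nM and compound 3 gives 92300 nM. For compound 2 this assay reports only a limit, > 100000 nM, not a number. The measured steps all stay within the scatter: an at least 1.9-fold higher number from compound 1 to compound 2 (0.27 log units; that floor lies within the scatter), a 1.8-fold higher number from compound 1 to compound 3 (0.25 log units; within the scatter) and an at least 1.0-fold lower number from compound 2 to compound 3 (0.03 log units; that floor lies within the scatter). Compound 4 `CCCCc1cc2ccccc2nc1-c1cc(-c2ccc(C(F)(F)F)cc2)no1` differs from compound 2 by trifluoromethyl in place of hydrogen on an aromatic carbon. Within the data shown here, no measured step concerns that six-membered ring; the chain steps offer no direction for this change. Compound 4 is therefore expected to give 90000 nM, with a range from 30000 nM to 300000 nM. The expected step is an at least 1.1-fold lower number from compound 2 to compound 4 (0.04 log units; that floor lies within the scatter), none beyond the scatter.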

Compound 4, half-maximal inhibitory concentration: 9400 nM
For compound 4 the middle estimate is 9.6-fold (0.98 log units) above the measured one, and the stated range ends above it.
By their numbers in this assay, from the lowest: compound 4; then compounds 1 and 3 (each within the scatter of the next). At a limit, above all of these: compound 2.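

In this assay, among these compounds, trifluoromethyl in place of hydrogen on an aromatic carbon, para to a large group, gives an at least 10-fold lower number from compound 2 to compound 4 (1.02 log units; beyond the scatter), the only step beyond the scatter. The six-membered ring thus responds to a change in a way that none of the chain steps showed. Compound 2 stands at a limit, so this step is a floor and its full size stays unknown: the limit of > 100000 nM in this assay, at which 1 of the 4 values shown sits.

The compounds shown leave open whether a chlorine, a methoxy or an amine at this place would do the same. They also leave open whether trifluoromethyl has a like effect on the chains of compound 1 and compound 3.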